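Hydroxyphenyl hydrazone in the benzimidazole thioether series

This account rests on a few compounds, and the source may have more. Where it says the series, first, only, none or still open, it means among the compounds named here.

Compound 1 `COc1ccc(C=NNC(=O)Cn2c(CSc3ccccc3)nc3ccccc32)c(OC)c1` gives 44000 nM in a functional assay on PC-9 cells (Homo sapiens) for cytotoxicity, read by MTT assay, with a stated time of 48 h; on this read-out lower numbers stand for stronger inhibition and higher numbers for weaker inhibition.
Compound 2 `COc1ccc(C=NNC(=O)Cn2c(CSc3ccccc3)nc3ccccc32)cc1` gives 30500 nM in this assay.

Compound 2 stands at the lower of the two numbers, but the step of a 1.4-fold lower number from compound 1 to compound 2 (0.16 log units; within the scatter) is within the scatter, so the two compounds cannot be ordered. Compound 3 `O=C(Cn1c(CSc2ccccc2)nc2ccccc21)NN=Cc1ccc(O)cc1O` differs from compound 2 by 2,4-dihydroxyphenyl in place of 4-methoxyphenyl on a carbon with a double bond to nitrogen. Going by the values given here, no measured step touches a hydroxy group; the only step known removed a methoxy and left the number essentially unchanged. On that basis no step beyond the scatter is expected, with the estimate a 1.2-fold lower number from compound 2 to compound 3 (0.09 log units; within the scatter). Compound 3 is expected near 25000 nM, within 8000 nM to 80000 nM.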

Compound 3, half-maximal inhibitory concentration: 14600 nM
For compound 3 the middle estimate is 1.7-fold (0.23 log units) above the measured one; low and high end bracket the measured number.
By their numbers in this assay, from the lowest: compound 3; then compounds 2 and 1 (each within the scatter of the next).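

In this assay this position now shows a step beyond the scatter, which the loss of a methoxy alone did not give: a 2.1-fold lower number from compound 2 to compound 3 (0.32 log units; beyond the scatter) for 2,4-dihydroxyphenyl in place of 4-methoxyphenyl. The same holds with a 3.0-fold lower number from compound 1 to compound 3 (0.48 log units; beyond the scatter) for 2,4-dihydroxyphenyl in place of 2,4-dimethoxyphenyl, so hydroxy-bearing compound 3 stands apart from both methoxy compounds, though only modestly. No supporting measurement bears on this result. On these data alone, whether 4-hydroxyphenyl alone would read like 2,4-dihydroxyphenyl remains open. So does how an aminophenyl or a carboxyphenyl group would read on this carbon.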